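This account rests on a few compounds, and the source may have more. Where it says the series, first, only, none or still open, it means among the compounds named here.

Within the data shown here, compound 2, `COc1ccc(/C=C\c2cc(OC)c(OC)c(OC)c2)cc1OCc1ccc(CN2CC[C@@H](O)C2)cc1`, is the one compound of this set for which an ADME assay on NCM460 cells (Homo sapiens) for cytotoxicity, read by CCK-8 assay, with a stated time of 48 h (a higher number here means a weaker inhibitor, a lower number a stronger inhibitor), yields a number: in this assay compound 2 gives 53000 nM. Compound 1, `COc1ccc(/C=C\c2cc(OC)c(OC)c(OC)c2)cc1OCc1ccc(CN2C[C@H](O)C[C@@H]2C(=O)O)cc1`, in this assay gives only a limit of > 50000 nM. Among the measured compounds shown here, the step that the limit leaves unreadable from compound 1 to compound 2 therefore cannot be sized, as the limit of > 50000 nM in this assay, at which 1 of the 2 values shown sits, shows, and it remains the sole measured step in the set.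

Compound 3, `COc1ccc(/C=C\c2cc(OC)c(OC)c(OC)c2)cc1OCc1ccc(CN2CCCCC2C(=O)NCCN)cc1`, differs from compound 2 in that (2-((2-aminoethyl)carbamoyl)piperidin-1-yl in place of 3-hydroxypyrrolidin-1-yl on a saturated chain carbon bound to an aromatic carbon). For the measured compounds named here, no measured step speaks to this change: the one step recorded is unreadable, so nothing in this assay points in either direction. The account therefore rests on compound 2 alone. Compound 3 is expected to lie near the value of compound 2, with a step of a 1.1-fold lower number from compound 2 to compound 3 (0.03 log units; within the scatter) that stays within the scatter and a real chance of ending as a limit. The estimate for compound 3 is 50000 nM, within a range from 20000 nM to 120000 nM.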

Compound 3, half-maximal inhibitory concentration: > 50000 nM
Compound 3: no number, only a limit; the forecaster's own chance of this, stated with the estimate: 45%; the middle value sits exactly at the limit.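

In this assay compound 3 gives only a limit of > 50000 nM. The steps linking compound 3 with compound 2 and compound 1 therefore cannot be read: the limit of > 50000 nM in this assay, at which 2 of the 3 values shown sit.

The compounds shown leave open whether either replacement on the saturated chain carbon bound to an aromatic carbon changes the result in this assay at all.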